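From Chloro to Bromo in an Antiproliferative Pair

The source may hold more compounds than are shown below. What is called first, only, known or untested is meant among the compounds shown, and "the series" means these compounds.

In a functional assay on A549 cells (Homo sapiens) for antiproliferative activity, read by MTT assay, with a stated time of 48 h (a lower number here means a stronger inhibitor, a higher number a weaker inhibitor), compound 1 (`O=[N+]([O-])c1cc(C(F)(F)F)cc([N+](=O)[O-])c1Oc1ccccc1/C=N\OCc1ccccc1`) gives 1470 nM as its half-maximal inhibitory concentration. Compound 2 (`O=[N+]([O-])c1cc(C(F)(F)F)cc([N+](=O)[O-])c1Oc1ccc(Cl)cc1/C=N\OCc1ccccc1`) gives 3410 nM and holds the higher of the two numbers, which makes it the weaker inhibitor of the measured pair.

Compound 3 (`O=[N+]([O-])c1cc(C(F)(F)F)cc([N+](=O)[O-])c1Oc1ccc(Br)cc1/C=N\OCc1ccccc1`) has not yet been measured. Its structure departs from that of compound 2 by bromo in place of chloro on an aromatic carbon with bromo in place of chloro on an aromatic carbon, meta to a large group and para to a large group.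

For the measured compounds named here, only one measured step bears on this change. The step of a 2.3-fold higher number from compound 1 to compound 2 (0.37 log units; beyond the scatter) comes with chloro in place of hydrogen on an aromatic carbon and is modest, though beyond the scatter. Going by the values given here, it does not exchange one halogen for another, so it offers only a loose guide, and no measured pair tests that exchange directly.

In this assay the estimate is a small step of a 1.1-fold lower number from compound 2 to compound 3 (0.06 log units; within the scatter) that stays within the scatter, with no clear direction expected. The estimate for compound 3 is 3000 nM with an expected range from 1400 nM to 6500 nM in this measurement.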

Compound 3, half-maximal inhibitory concentration: 2240 nM
Compound 3: the middle estimate sits 1.3-fold (0.13 log units) above what was measured; the range from low to high includes it.
By their numbers in this assay, from the lowest: compounds 1, 3 and 2 (each within the scatter of the next, the first and the last beyond it).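

In this assay, bromo in place of chloro on this aromatic carbon, meta to a large group and para to a large group, gives a 1.5-fold lower number from compound 2 to compound 3 (0.18 log units; within the scatter) and so adds a second halogen whose number cannot be told apart from that of the first. The comparison with hydrogen is less uniform than the chloro pair alone suggested: bromo in place of hydrogen gives a 1.5-fold higher number from compound 1 to compound 3 (0.18 log units; within the scatter) and chloro in place of hydrogen gives a 2.3-fold higher number from compound 1 to compound 2 (0.37 log units; beyond the scatter), so only chloro is separated from hydrogen, while bromo sits within the scatter of both neighbours and a halogen at this position does not by itself mark a step beyond the scatter. The data shown offer nothing that accounts for these numbers.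

On these data alone, whether a fluoro group, a methoxy group, an amine or a carboxylic acid at this same carbon would stay close to the halogens or move clearly away from them remains open. With only hydrogen, chloro and bromo shown at one position, it is also unknown whether the same small steps would appear at any other carbon of this ring.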